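Trifluoromethyl in place of methyl: compound 1 to compound 3

This account rests on a few compounds, and the source may have more. Where it says the series, first, only, none or still open, it means among the compounds named here.

For the measured compounds named here, in a functional assay on MCF7 cells (Homo sapiens) for antiproliferative activity, read by MTT assay, with a stated time of 24 h (on this read-out higher numbers stand for weaker inhibition and lower numbers for stronger inhibition), compound 1 `Cc1ccc(-c2nn(-c3ccccc3)cc2-c2nc3ccccc3n2S(=O)(=O)c2cc(C)ccc2C)cc1` gives 510 nM and stands lowest of the two numbers so far, while compound 2 `Cc1ccc(-c2nn(-c3ccccc3)cc2-c2nc3ccccc3n2S(=O)(=O)c2ccc(C(F)(F)F)cc2)cc1` gives 2340 nM. By trifluoromethyl in place of methyl on an aromatic carbon compound 3 `Cc1ccc(C)c(S(=O)(=O)n2c(-c3cn(-c4ccccc4)nc3-c3ccc(C(F)(F)F)cc3)nc3ccccc32)c1` departs from compound 1 at one place: trifluoromethyl in place of methyl on an aromatic carbon, 4-methylphenyl to 4-(trifluoromethyl)phenyl. Going by the values given here, the sole measured step a 4.6-fold higher number from compound 1 to compound 2 (0.66 log units; beyond the scatter) also brings in a trifluoromethyl group, but at another place, so it is only a loose guide. A rise of smaller size is expected in this assay, and the expected step is a 2.0-fold higher number from compound 1 to compound 3 (0.29 log units; within the scatter). Compound 3 is estimated at 1000 nM with a range from 330 nM to 3000 nM.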

Compound 3, half-maximal inhibitory concentration: 170 nM
Compound 3: middle estimate off by 5.9-fold (0.77 log units), on the high side, and the stated range ends above it.
By their numbers in this assay, from the lowest: compound 3; then compound 1; then compound 2.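

In this assay, for the compounds shown here, 4-(trifluoromethyl)phenyl in place of 4-methylphenyl gives a 3.0-fold lower number from compound 1 to compound 3 (0.48 log units; beyond the scatter), the only change so far that lowers the number. This position therefore accepts trifluoromethyl in place of methyl, and the result on the sulfonyl side, a 4.6-fold higher number from compound 1 to compound 2 (0.66 log units; beyond the scatter), does not carry over to it. Nothing available here explains the difference in direction.

Going by these compounds, it remains open whether the lower number is particular to trifluoromethyl or would also come with chlorine, a methoxy group or a nitrile on this ring. On these data alone, it is also open whether the change would hold with 4-(trifluoromethyl)phenyl on the sulfonyl sulfur.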